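From 3-nitrophenyl to 2-nitrophenyl in compound 2

The compounds below may be only part of what the source reports. "The series", "measured", "known", "first", "only" and "open" are said of these compounds alone.

Measured so far in a physicochemical assay, with a stated time of 6 min (a higher number here means a weaker inhibitor, a lower number a stronger inhibitor), are three compounds.

Compound 1 `O=C(Nc1ccc([N+](=O)[O-])cc1)Nc1nc(-c2cc3ccccc3o2)cs1` gives 19300 nM here
Compound 2 `O=C(Nc1cccc([N+](=O)[O-])c1)Nc1nc(-c2cc3cc(Br)ccc3o2)cs1` gives 159000 nM here
Compound 3 `O=C(Nc1cccc(Cl)c1)Nc1nc(-c2cc3ccccc3o2)cs1` gives 14100 nM here

Compound 2 carries the highest number of the three at 159000 nM while compound 1 stands at 19300 nM and compound 3 stands at 14100 nM in the same read-out.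

Compound 4 `O=C(Nc1nc(-c2cc3cc(Br)ccc3o2)cs1)Nc1ccccc1[N+](=O)[O-]` has not yet been measured. It differs from compound 2 as follows: 2-nitrophenyl in place of 3-nitrophenyl on an amide-type nitrogen with 2-nitrophenyl in place of 3-nitrophenyl on an amide-type nitrogen.

Among the measured compounds shown here, no measured pair shows this exact change. For the measured compounds named here, the only measured step at that amide-type nitrogen is a 1.4-fold lower number from compound 1 to compound 3 (0.14 log units; within the scatter) and it lies within the scatter. On that slim evidence, no step beyond the scatter is expected in this assay and no firm direction can be given. The estimated step is a 1.1-fold lower number from compound 2 to compound 4 (0.06 log units; within the scatter) and it is expected to stay within the scatter. Compound 4 is expected at 140000 nM and is estimated to fall from 45000 nM to 450000 nM on repeated measurement.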

Compound 4, half-maximal inhibitory concentration: 166000 nM
For compound 4 the middle estimate is 1.2-fold (0.07 log units) below the measured one, and the stated range covers the measured number.
By their numbers in this assay, from the lowest: compounds 3 and 1 (each within the scatter of the next); then compounds 2 and 4 (each within the scatter of the next).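

In this assay, among the compounds shown here, 2-nitrophenyl in place of 3-nitrophenyl on an amide-type nitrogen gives a 1.0-fold higher number from compound 2 to compound 4 (0.02 log units; within the scatter), the first measured step at that nitrogen among compounds carrying bromine and the first to exchange one nitrophenyl for another. Like a 1.4-fold lower number from compound 1 to compound 3 (0.14 log units; within the scatter), it lies within the scatter, so neither change measured at this nitrogen separates its pair in this read-out. No measurement shown here bears on the reason for this result.

The compounds shown leave open whether an aminophenyl, a carboxylic acid on the phenyl ring or a longer chain at that nitrogen would give a step beyond the scatter. They also leave open what the bromine alone contributes, as no pair shown differs by that atom only.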